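The source may report more compounds than this note shows. Statements on the series, on what has been measured and on what is new or still open speak of the compounds shown alone.

Compound 1 `O=C(CN1CCN(C(=O)c2ccc(F)cc2)CC1)N1CCN(CCCc2c[nH]c3ccc(F)cc23)CC1`: 102000 nM
Compound 2 `COc1ccc2[nH]cc(CCCN3CCN(C(=O)CN4CCN(C(=O)c5ccc(Br)cc5)CC4)CC3)c2c1`: 80500 nM

Both values come from an ADME assay on HEK293 cells (Homo sapiens) for cytotoxicity, read by MTT assay, with a stated time of 72 h; on this read-out higher numbers stand for weaker inhibition and lower numbers for stronger inhibition. Compound 2 stands level with compound 1, as their two numbers lie within the usual scatter of each other. Compound 3 `COc1ccc2[nH]cc(CCCN3CCN(C(=O)CN4CCN(C(=O)c5ccc(F)cc5)CC4)CC3)c2c1` differs from compound 2 at a single place, on an aromatic carbon: fluoro in place of bromo on an aromatic carbon. Among the compounds with values here, no two measured compounds differ in only one place, so the data show no direct step of this kind. A step beyond the scatter is not expected, and the expected step of a 1.1-fold higher number from compound 2 to compound 3 (0.05 log units; within the scatter) is small. For compound 3 the estimated value is 90000 nM, with an expected range of 50000 nM to 160000 nM.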

Compound 3, half-maximal inhibitory concentration: > 200000 nM
Compound 3: a limit, no number; the forecaster's own chance of this, stated with the estimate: 15%; at least 2.2-fold (0.34 log units) between middle value and limit.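

In this assay, fluoro in place of bromo on this aromatic carbon, para to a large group, gives an at least 2.4-fold higher number from compound 2 to compound 3 (0.39 log units; beyond the scatter), so the halogen here does affect the read-out. Compound 3 reads > 200000 nM, a limit of the assay and not a number, so this step has only a floor: the limit of > 200000 nM in this assay, at which 1 of the 3 values shown sits.
Methoxy in place of fluoro on an aromatic carbon of the core gives an at least 1.9-fold higher number from compound 1 to compound 3 (0.29 log units; that floor lies within the scatter), and that floor alone shows no change. As far as these compounds go, how far compound 3 lies past its limit stays open, as does whether chloro or an amine at the bromo position would read like bromo or like fluoro.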